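Pyrrole Gives Way to Bromofuran on the Acrylamide Chain

The source may report more compounds than this note shows. Statements on the series, on what has been measured and on what is new or still open speak of the compounds shown alone.

Compound 1, `N#C/C(=C\c1c[nH]c2ccccc12)C(=O)c1c[nH]c2ccccc12`: 7600 nM
Compound 2, `COc1ccc(CNC(=O)/C(C#N)=C/c2ccc[nH]2)cc1`: > 50000 nM

In a functional assay on A-431 cells (Homo sapiens) for inhibition, read by MTT assay, with a stated time of 72 h (a higher number here means a weaker inhibitor of growth, a lower number a stronger inhibitor of growth), compound 1 gives 7600 nM. Compound 2 is reported in this assay only as a limit, > 50000 nM, so its true standing is not known. It sits at the limit of > 50000 nM in this assay, at which 1 of the 2 values shown sits. Compound 3, `COc1ccc(CNC(=O)/C(C#N)=C/c2cc(Br)co2)cc1`, differs from compound 2 by 4-bromofuran-2-yl in place of 1H-pyrrol-2-yl on a double-bonded chain carbon bound to a double-bonded chain carbon. Within the data shown here, no step between measured compounds exists here, so this change has no precedent in the data. Compound 3 is expected to stay near that limit, with the step of a number no higher from compound 2 to compound 3 (the limit leaves the size open) estimated as none beyond the scatter. Compound 3 is therefore estimated at 50000 nM, between 15000 nM and 150000 nM.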

Compound 3, concentration for 50% growth inhibition: 14000 nM
Compound 3: the middle estimate sits 3.6-fold (0.55 log units) above what was measured; measured number below the stated range.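

In this assay, 4-bromofuran-2-yl in place of 1H-pyrrol-2-yl on a double-bonded chain carbon bound to a double-bonded chain carbon gives an at least 3.5-fold lower number from compound 2 to compound 3 (0.55 log units; beyond the scatter). Among these compounds, this is the first sign that growth inhibition responds to the group at this place on the chain. The full size of the step stays unknown because compound 2 stands only at a limit: the limit of > 50000 nM in this assay, at which 1 of the 3 values shown sits.

The compounds shown do not separate the part played by the furan ring from that of the bromine. A plain furan-2-yl or a bromopyrrole at this place would tell the two apart.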